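A new side group on a shared core

The compounds below may be only part of what the source reports. "The series", "measured", "known", "first", "only" and "open" are said of these compounds alone.

Compound 1 `Cc1cc(OCc2cn(-c3ccc(NS(C)(=O)=O)c(Oc4ccccc4)c3)nn2)ccc1Cl` – 7900 nM
Compound 2 `Cc1ccc(-c2cn(-c3ccc(NS(C)(=O)=O)c(Oc4ccccc4)c3)nn2)cc1` – "not determined" (no result reported)

In a functional assay on HeLa cells (Homo sapiens) for inhibition, read by MTT assay, with a stated time of 48 h (a lower number here means a stronger inhibitor, a higher number a weaker inhibitor), compound 2 stands at "not determined" (no result reported) and so offers no number to start from. The structural change (4-chlorophenoxy)methyl in place of 4-methylphenyl on an aromatic carbon places (4-chlorophenoxy)methyl in place of 4-methylphenyl on an aromatic carbon. It gives compound 3 `CS(=O)(=O)Nc1ccc(-n2cc(COc3ccc(Cl)cc3)nn2)cc1Oc1ccccc1` which has not yet been tested. Among the compounds with values here, with no measured step to guide the size of a change, the only level available in this assay is that of compound 1 at 7900 nM and no shift beyond the usual scatter from that level, in either direction, is expected. Compound 3 is estimated at 8000 nM (3500 nM to 18000 nM).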

Compound 3, half-maximal inhibitory concentration: 7800 nM
Compound 3: middle estimate off by 1.0-fold (0.01 log units), on the high side; the measured number falls inside the stated range.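

In this assay, hydrogen in place of methyl on an aromatic carbon of the side group gives a 1.0-fold lower number from compound 1 to compound 3 (0.01 log units; within the scatter), so compound 1 and compound 3 read alike and this methyl does not move the result beyond the scatter. Nothing measured here offers an explanation for this. Compound 2 has no number, so the swap of 4-methylphenyl for (4-chlorophenoxy)methyl cannot be read.

As far as these compounds go, what an amine or a carboxylic acid would do on that same carbon remains open. So does the effect of a longer chain linking the side group to the shared core.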